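The source may hold more compounds than are shown below. What is called first, only, known or untested is meant among the compounds shown, and "the series" means these compounds.

In an ADME assay on the whole organism (blood, Mus musculus, strain C57BL/6) for pharmacokinetics, read by HPLC, with a stated time of 4 h, at a dose of 2 mg/kg by the intraperitoneal route (a lower number here means less compound in the circulation, a higher number more compound in the circulation at the dose given), two compounds sharing one core have been followed. Compound 1 (`CC(C)S(=O)(=O)c1c(Cl)ccc(NC(=O)Nc2cccc(F)c2Cl)c1O`) gives 198 ng.h/mL and compound 2 (`C[C@@H]1CN(S(=O)(=O)c2c(Cl)ccc(NC(=O)Nc3cccc(F)c3Cl)c2O)C[C@H](C)O1`) gives 279 ng.h/mL, two numbers that lie within the scatter of each other. Compound 3 (`CCN1CCN(S(=O)(=O)c2c(Cl)ccc(NC(=O)Nc3cccc(F)c3Cl)c2O)CC1`) keeps the core of compound 2 and carries 4-ethylpiperazin-1-yl in place of 2,6-dimethylmorpholin-4-yl on a sulfonyl sulfur. The counted difference is 4-ethylpiperazin-1-yl in place of 2,6-dimethylmorpholin-4-yl on a sulfonyl sulfur. Among the measured compounds shown here, one measured step bears on this place, a 1.4-fold higher number from compound 1 to compound 2 (0.15 log units; within the scatter), where 2,6-dimethylmorpholin-4-yl took the place of isopropyl. For the measured compounds named here, no measured compound carries 4-ethylpiperazin-1-yl, so the evidence is thin. On that basis no step beyond the scatter is expected in this assay, in either direction. The estimated change is a 1.1-fold lower number from compound 2 to compound 3 (0.05 log units; within the scatter). For compound 3 the expected value is 250 ng.h/mL, with an estimated range from 100 ng.h/mL to 600 ng.h/mL.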

Compound 3, area under the concentration-time curve: 189 ng.h/mL
The estimate for compound 3 lay 1.3-fold (0.12 log units) above the measured number, and the stated range covers the measured number.
By their numbers in this assay, from the lowest: compounds 3, 1 and 2 (each within the scatter of the next).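

In this assay the exchange of 2,6-dimethylmorpholin-4-yl for 4-ethylpiperazin-1-yl on a sulfonyl sulfur gives a 1.5-fold lower number from compound 2 to compound 3 (0.17 log units; within the scatter) and the exchange of isopropyl for 4-ethylpiperazin-1-yl gives a 1.0-fold lower number from compound 1 to compound 3 (0.02 log units; within the scatter) at the same place. Isopropyl and two different six-membered non-aromatic rings, one with defined stereocentres and one without, thus all lie within the scatter of one another, where earlier only a single pair could be compared. Nothing measured here accounts for this result.

From the compounds shown here alone, what a carboxylic acid, a primary amine or a longer alkyl chain on the sulfonyl sulfur would do to the circulating amount remains open. So does the question of whether any change elsewhere on the shared core would give a step beyond the scatter in this assay at this dose.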